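From 3,4-dimethoxyphenyl to 2,3-dimethoxyphenyl: compound 4 awaits measurement

The compounds below may be only part of what the source reports. "The series", "measured", "known", "first", "only" and "open" are said of these compounds alone.

Values in a functional assay on ECa-109 cells (Homo sapiens) for cytotoxicity, read by MTT assay, with a stated time of 72 h; a higher number here means a weaker inhibitor, a lower number a stronger inhibitor:
- compound 1 `O=C1C(=Cc2ccc(Cl)cc2)C(=O)N(c2ccc(Cl)cc2)N1c1ccc(Cl)cc1`: 17300 nM
- compound 2 `O=C1C(=Cc2ccc(Br)cc2)C(=O)N(c2ccc(Cl)cc2)N1c1ccc(Cl)cc1`: 12300 nM
- compound 3 `COc1ccc(C=C2C(=O)N(c3ccc(Cl)cc3)N(c3ccc(Cl)cc3)C2=O)cc1OC`: > 128000 nM (a limit, not a number)

Compound 3 gives only a limit and no number, > 128000 nM in this assay. Compound 4 `COc1cccc(C=C2C(=O)N(c3ccc(Cl)cc3)N(c3ccc(Cl)cc3)C2=O)c1OC` has the same atoms joined differently: 2,3-dimethoxyphenyl in place of 3,4-dimethoxyphenyl on a double-bonded chain carbon bound to a double-bonded ring carbon. Here, 2,3-dimethoxyphenyl takes the place of 3,4-dimethoxyphenyl on a double-bonded chain carbon bound to a double-bonded ring carbon.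

Going by the values given here, no measured step shows such a rearrangement. The nearest are an at least 7.3-fold higher number from compound 1 to compound 3 (0.86 log units; beyond the scatter) and an at least 10-fold higher number from compound 2 to compound 3 (1.01 log units; beyond the scatter), both beyond the scatter, and each brings in the 3,4-dimethoxyphenyl at that same place. The remaining step, a 1.4-fold lower number from compound 1 to compound 2 (0.15 log units; within the scatter), lies within the scatter and concerns only a bromo in place of a chloro.

Compound 4 still carries a dimethoxyphenyl, the kind of group that arrived with an at least 10-fold higher number from compound 2 to compound 3 (1.01 log units; beyond the scatter), so it is expected to stay close to compound 3, with no step beyond the scatter in either direction. The expected change is an at least 1.1-fold lower number from compound 3 to compound 4 (0.06 log units; that floor lies within the scatter). For compound 4 the estimated value is 110000 nM, with an expected range of 40000 nM to 250000 nM.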

Compound 4, half-maximal inhibitory concentration: 6800 nM
The estimate for compound 4 lay 16-fold (1.21 log units) above the measured number; the measured number lies below the stated range.
By their numbers in this assay, from the lowest: compounds 4, 2 and 1 (each within the scatter of the next, the first and the last beyond it). At a limit, above all of these: compound 3.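

In this assay, 2,3-dimethoxyphenyl in place of 3,4-dimethoxyphenyl on a double-bonded chain carbon bound to a double-bonded ring carbon gives an at least 18-fold lower number from compound 3 to compound 4 (1.27 log units; beyond the scatter), so at this place the arrangement of the two methoxy groups matters, even with the atoms unchanged. The earlier compounds shown here could have suggested that a dimethoxyphenyl at this place goes with weak inhibition, yet 2,3-dimethoxyphenyl in place of 4-bromophenyl gives a 1.8-fold lower number from compound 2 to compound 4 (0.26 log units; within the scatter), which stays within the scatter, and 2,3-dimethoxyphenyl in place of 4-chlorophenyl gives a 2.5-fold lower number from compound 1 to compound 4 (0.41 log units; beyond the scatter), which lies beyond it. The size of the first step has only a floor, since compound 3 is known only as a limit and not as a number: the limit of > 128000 nM in this assay, at which 1 of the 4 values shown sits.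

The compounds shown leave open how a phenyl ring with a single methoxy group, or with a hydroxyl group or an amine, would behave at this place. They also leave open whether the gap between the two dimethoxyphenyl arrangements holds in any cells other than those of this assay.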